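The source may report more compounds than this note shows. Statements on the series, on what has been measured and on what is new or still open speak of the compounds shown alone.

For the measured compounds named here, compound 1 `Cc1cc(Br)c(Oc2nc(Nc3ccc(C#N)cc3)nc3ccccc23)c(Br)c1` holds the lower of the two numbers so far: in an ADME assay on MT4 cells (Homo sapiens) for cytotoxicity, read by MTT assay, with a stated time of 4 days (on this read-out higher numbers stand for lower toxicity in this test and lower numbers for higher toxicity in this test), compound 1 gives 25000 nM, while compound 2 `COc1cc(C#N)cc(Cl)c1Oc1nc(Nc2ccc(C#N)cc2)nc2ccccc12` gives 220000 nM in this assay, a gap beyond the usual scatter. Compound 3 `Cc1cc(C)c(Oc2nc(Nc3ccc(C#N)cc3)nc3ccccc23)c(C)c1` differs from compound 1 by 2,4,6-trimethylphenyl in place of 2,6-dibromo-4-methylphenyl on an oxygen on an aromatic ring. Going by the values given here, no pair of measured compounds differs in only that place, so the size of the step is uncertain; a modest shift toward lower toxicity in this assay is expected, though it may well stay within the scatter. The estimate for compound 3 in this assay is 40000 nM, with a range from 12000 nM to 130000 nM. That expectation amounts to a step of a 1.6-fold higher number from compound 1 to compound 3 (0.20 log units; within the scatter).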

Compound 3, half-maximal cytotoxic concentration: > 34000 nM
Compound 3: no number, only a limit; the forecaster's own chance of this, stated with the estimate: 20%; the middle value is on the limit's open side.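

In this assay compound 3 gives > 34000 nM, which is a limit of the assay and not a number. With 2,4,6-trimethylphenyl in place of 2,6-dibromo-4-methylphenyl on the oxygen, the change gives an at least 1.3-fold higher number from compound 1 to compound 3 (0.13 log units; that floor lies within the scatter). On these data alone, this shows that the position takes a group of carbon alone without a fall in the number, but only a floor can be read, so the true size of the step stays unknown. As far as these compounds go, whether the step goes beyond the scatter remains open. Also open, from the compounds shown here alone, is how the read-out would respond if a phenyl ring bearing an amine or a carboxylic acid stood on that oxygen.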